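This account rests on a few compounds, and the source may have more. Where it says the series, first, only, none or still open, it means among the compounds named here.

Compound 1, with the structure `COc1ccc2[nH]c(C(=O)N3CC(=O)N(Cc4ccccc4)[C@@H](CN4CCC5(CC4)CC5)C3)cc2c1`, and compound 2, with the structure `COc1ccc2[nH]c(C(=O)N3CC(=O)N(Cc4ccccc4)[C@@H](N4CCC(Cc5ccccc5)CC4)C3)cc2c1`, share one core and differ only in the group carried on the saturated ring. In an ADME assay on microsomes from liver (Homo sapiens) for metabolic stability, with a stated time of 30 min, tested at 1 uM (on this read-out lower numbers stand for a shorter-lived compound and higher numbers for a longer-lived compound), compound 1 gives 0.867 h. In this assay compound 2 gives 0.597 h. Compound 1 has the higher of these two numbers, but the gap to compound 2 is within the usual scatter, so the two results cannot be told apart with confidence.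

Compound 3, with the structure `COc1ccc2[nH]c(C(=O)N3CC(=O)N(Cc4ccccc4)[C@@H](CN4CCCc5ccccc54)C3)cc2c1`, has not yet been measured. It differs from compound 1 in one place: a group of 10 heavy atoms (9 carbon, 1 nitrogen; one six-membered non-aromatic ring with 1 hetero atom, one six-membered aromatic ring of carbon only) in place of a group of 8 heavy atoms (7 carbon, 1 nitrogen; one three-membered non-aromatic ring of carbon only, one six-membered non-aromatic ring with 1 hetero atom), on a saturated chain carbon bound to a saturated ring carbon. Within the data shown here, no step between measured compounds of this kind is available, so nothing measured tells how large a step to expect. The expectation for compound 3 is that the step of a 1.3-fold lower number from compound 1 to compound 3 (0.13 log units; within the scatter) stays within the scatter. Compound 3 is therefore estimated at 0.65 h, with a likely range from 0.3 h to 1.4 h.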

Compound 3, half-life: 0.183 h
Compound 3: middle estimate off by 3.6-fold (0.55 log units), on the high side; the whole stated range lies above it.
By their numbers in this assay, from the lowest: compound 3; then compounds 2 and 1 (each within the scatter of the next).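

Putting 1,2,3,4-tetrahydroquinolin-1-yl in place of the group that compound 1 carries on a saturated chain carbon bound to a saturated ring carbon brings a 4.7-fold lower number from compound 1 to compound 3 (0.68 log units; beyond the scatter) in this assay and gives the first clear difference in this small set. The numbers for compound 1 and compound 2 could not be told apart, whereas this result shows that half-life in this test can respond to a change at this position. Nothing available explains why the number falls with this change.

The whole group changes in this single step, so the data cannot separate the part played by the added six-membered aromatic ring of carbon only from that of the lost three-membered ring. As far as these compounds go, how an open-chain group such as diethylamino, or a carboxylic acid, would behave at this position remains open.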